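The compounds below may be only part of what the source reports. "The series", "measured", "known", "first", "only" and "open" are said of these compounds alone.

Compound 1 `CC(C)n1ncc2c(C(=O)Nc3ccc(F)cc3)cc(-c3cccs3)nc21`: > 200000 nM
Compound 2 `CC(C)n1ncc2c(C(=O)Nc3ccccn3)cc(C3CC3)nc21`: 25000 nM
Compound 3 `CC(C)n1ccc2c(C(=O)Nc3cccnc3)cc(-c3cccs3)nc21`: 25000 nM

All three were examined in an ADME assay on LLC-MK2 cells (Macaca mulatta) for cytotoxicity, read by spectrophotometry and crystal violet staining, with a stated time of 4 days; on this read-out higher numbers stand for lower toxicity in this test and lower numbers for higher toxicity in this test. Compound 1 did not reach a measurable number; for it only the limit of > 200000 nM in this assay, at which 1 of the 3 values shown sits, is known, a bound of the assay rather than a value. Compound 2, with a cyclopropyl group on the shared core and a pyridin-2-yl amide, gives 25000 nM in this assay. Compound 3, which carries the thiophene and a pyridin-3-yl amide on a differently built core, gives 25000 nM in this assay, so both measured numbers sit at the same point within the usual scatter.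

Compound 4 `CC(C)n1ncc2c(C(=O)Nc3cccnc3)cc(-c3cccs3)nc21` has not yet been measured. It differs from compound 1 in one place: pyridin-3-yl in place of 4-fluorophenyl on an amide-type nitrogen. Since compound 1 stands only at a limit, no measured size for such a change is available, and the expectation in this assay is a move toward higher toxicity of modest size, possibly within the scatter. Compound 4 is therefore expected to give 70000 nM, between 20000 nM and 200000 nM, a step of an at least 2.8-fold lower number from compound 1 to compound 4 (0.45 log units; beyond the scatter) being the estimate.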

Compound 4, half-maximal cytotoxic concentration: > 200000 nM
Compound 4 ended at the assay's limit (the forecaster's own chance of this, stated with the estimate: 30%); middle value at least 2.8-fold (0.45 log units) away from the limit.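

Compound 1 and compound 4 both stand at a limit, not at a number, so no step between them can be read: the limit of > 200000 nM in this assay, at which 2 of the 4 values shown sit.

The compounds shown leave open what pyridin-3-yl in place of 4-fluorophenyl on an amide-type nitrogen does in this assay.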